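The compounds below may be only part of what the source reports. "The series", "measured", "known", "first", "only" and "open" are said of these compounds alone.

Series notes. Three compounds share a thiazole core bearing a trifluoromethyl group and a hydrazone arm; compound 1 `CNc1nc(C(F)(F)F)c(C(=O)N/N=C/c2cccc(C(F)(F)F)c2)s1` carries a methylamino group on the core, while compound 3 `CN(C(=O)NC(=O)c1cccc(C(F)(F)F)c1)c1nc(C(F)(F)F)c(C(=O)N/N=C/c2cccc(C(F)(F)F)c2)s1` and compound 2 `CN(C(=O)NC(=O)c1cccc(C(F)(F)F)c1)c1nc(C(F)(F)F)c(C(=O)N/N=C/c2cc(C(F)(F)F)cc(C(F)(F)F)c2)s1` carry an acylurea in that position. The difference between the core of compound 1 and the core of compound 3 is not broken down here.

In a functional assay on MCF7 cells (Homo sapiens) for inhibition, read by MTT assay, with a stated time of 72 h (on this read-out lower numbers stand for stronger inhibition and higher numbers for weaker inhibition), compound 3 gives 3.7 ug/mL. In this assay compound 2 gives 6.08 ug/mL. The change between them is trifluoromethyl in place of hydrogen on an aromatic carbon; the step it made was a 1.6-fold higher number from compound 3 to compound 2 (0.22 log units; within the scatter), so the two values cannot be told apart.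

For compound 1 only a limit is known: in this assay compound 1 gives > 100 ug/mL, which is a limit of the assay and not a number (the limit of > 100 ug/mL in this assay, at which 1 of the 3 values shown sits).

Compound 4 `CNc1nc(C(F)(F)F)c(C(=O)N/N=C/c2cc(C(F)(F)F)cc(C(F)(F)F)c2)s1` has not yet been measured in this assay. It differs from compound 1 by trifluoromethyl in place of hydrogen on an aromatic carbon, the same change already made from compound 3 to compound 2. Since that measured step, a 1.6-fold higher number from compound 3 to compound 2 (0.22 log units; within the scatter), sat within the scatter, the expected step from compound 1 to compound 4 is a step that the limit leaves unreadable from compound 1 to compound 4, and it rests on that single earlier pair. Because compound 1 itself gave only a limit > 100 ug/mL, compound 4 is expected to sit near or at the same limit as well. The estimate for compound 4 in this assay is 130 ug/mL, with an expected range from 40 ug/mL to 400 ug/mL.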

Compound 4, half-maximal inhibitory concentration: > 100 ug/mL
Compound 4: no number, only a limit; the forecaster's own chance of this, stated with the estimate: 70%; the middle value lies beyond the limit too.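

In this assay compound 4 gives > 100 ug/mL, which is a limit of the assay and not a number. Compound 1 also stands at a limit, so no step between compound 1 and compound 4 can be read: the limit of > 100 ug/mL in this assay, at which 2 of the 4 values shown sit.

The compounds shown leave open what trifluoromethyl in place of hydrogen on an aromatic carbon does to the read-out on the core of compound 1.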